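From chloromethyl to pyridin-4-yl: compound 1 to compound 4

The source may hold more compounds than are shown below. What is called first, only, known or untested is meant among the compounds shown, and "the series" means these compounds.

Compound 1 `C/C(=N\Nc1nc(CCl)cs1)c1ccc(Cl)c(Cl)c1`: > 50000 nM (a limit)
Compound 2 `C/C(=N\Nc1nc(C)c(C)s1)c1ccc(Cl)c(Cl)c1`: 41800 nM
Compound 3 `C/C(=N\N=c1\scc(-c2ccccc2)n1-c1ccccc1)c1ccc(Cl)c(Cl)c1`: > 50000 nM (a limit)
Compound 4 `C/C(=N\Nc1nc(-c2ccncc2)cs1)c1ccc(Cl)c(Cl)c1`: not yet measured

In an ADME assay on J774 cells (Mus musculus) for cytotoxicity, read by resazurin assay, with a stated time of 72 h (on this read-out higher numbers stand for lower toxicity in this test and lower numbers for higher toxicity in this test), compound 1 sits at the limit of > 50000 nM in this assay, at which 2 of the 3 values shown sit. That makes its entry a limit and not a number. Compound 2 gives an actual number, 41800 nM.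

Compound 4 has pyridin-4-yl in place of chloromethyl on an aromatic carbon. Among the compounds with values here, no measured pair of compounds differs in one place, so the data give no direct guide to this step. A modest fall in this assay is expected, going by compound 2 at 41800 nM. Compound 4 is estimated at 35000 nM, with an expected range of 12000 nM to 50000 nM. The estimated change is an at least 1.4-fold lower number from compound 1 to compound 4 (0.15 log units; that floor lies within the scatter).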

Compound 4, half-maximal cytotoxic concentration: 39800 nM
The estimate for compound 4 lay 1.1-fold (0.06 log units) below the measured number, within the range that was stated.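

Within the data shown here, this is the first step between measured compounds that differ in one place: in this assay, pyridin-4-yl in place of chloromethyl on this aromatic carbon gives an at least 1.2-fold lower number from compound 1 to compound 4 (0.09 log units; that floor lies within the scatter). Even with a six-membered aromatic ring at this place, the step cannot be told apart from the scatter. It can be read only as a floor because the entry for compound 1 is a limit and not a number: the limit of > 50000 nM in this assay, at which 2 of the 4 values shown sit.

Going by these compounds, what an amine or a carboxylic acid on this carbon would do remains open.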